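Replacing tert-Butyl by Cyano on the Aromatic Ring

This account rests on a few compounds, and the source may have more. Where it says the series, first, only, none or still open, it means among the compounds named here.

In a functional assay on ACHN cells (Homo sapiens) for inhibition, read by sulforhodamine B assay (a lower number here means a stronger inhibitor of growth, a higher number a weaker inhibitor of growth), compound 2 `CC(C)(C)c1ccc(CN2CC=C(CCC(=O)NO)C2=O)cc1` gives 860 nM, the lowest of the two numbers measured. Compound 1 `Cc1ccc(CN2CC=C(CCC(=O)NO)C2=O)cc1` gives 3330 nM. Going by the values given here, the only measured step, a 3.9-fold lower number from compound 1 to compound 2 (0.59 log units; beyond the scatter), sets tert-butyl against methyl and does not cover cyano. Compound 3 `N#Cc1ccc(CN2CC=C(CCC(=O)NO)C2=O)cc1` differs from compound 2 by cyano in place of tert-butyl on an aromatic carbon. Among the compounds with values here, with no step bearing directly on cyano, the expectation is a number somewhere between the two known values. Compound 3 is therefore estimated at 2500 nM, within 800 nM to 8000 nM, which means an expected step of a 2.9-fold higher number from compound 2 to compound 3 (0.46 log units; beyond the scatter).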

Compound 3, concentration for 50% growth inhibition: > 10000 nM
Compound 3 ended at the assay's limit (the forecaster's own chance of this, stated with the estimate: 5%); at least 4.0-fold (0.60 log units) between middle value and limit.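

Compound 3 stands at a limit of the assay, not at a number: the limit of > 10000 nM in this assay, at which 1 of the 3 values shown sits. Even so, the change at this aromatic carbon shows an at least 11-fold higher number from compound 2 to compound 3 (1.06 log units; beyond the scatter), and also an at least 3.0-fold higher number from compound 1 to compound 3 (0.47 log units; beyond the scatter). In this assay, going by these compounds alone, cyano therefore gives a weaker inhibitor of growth than either tert-butyl or methyl, whereas the earlier compounds had compared only those two groups.

As far as these compounds go, how far compound 3 lies past the limit remains open, so both steps have only a lower bound. From the compounds shown here alone, it also remains open whether an amine, a carboxylic acid or a methoxy group here would stay near compound 2 or fall away like cyano.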